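Para-chloro removal on the aryl arm of the shared core

The source may report more compounds than this note shows. Statements on the series, on what has been measured and on what is new or still open speak of the compounds shown alone.

Measured so far:
compound 1 `S=c1s/c(=N\c2ccc(Cl)cc2)n2n1CCCC2`: 234 nM
compound 2 `Fc1cc(Cl)ccc1-n1c(=S)n2n(c1=S)CCCC2`: 18.2 nM

In a functional assay on the whole organism with Scenedesmus acutus as the target, read by spectrophotometry (a higher number here means a weaker inhibitor, a lower number a stronger inhibitor), compound 1 gives 234 nM, the highest of the two numbers; compound 2 gives 18.2 nM, a lower number and beyond the scatter of compound 1, so compound 2 is the stronger inhibitor of the pair. The two differ in more than one place, so no single step can be read from them.

Compound 3 `S=c1s/c(=N\c2ccccc2)n2n1CCCC2` is not yet measured. The change from compound 1 is hydrogen in place of chloro on an aromatic carbon, on an aromatic carbon of a six-membered aromatic ring of carbon only, para to a large group. Without a measured step for this change, the expectation rests on compound 1 alone: a loss of one chlorine is expected to give a modest rise in the number, the step of a 2.1-fold higher number from compound 1 to compound 3 (0.33 log units; beyond the scatter) likely near the edge of the scatter. Compound 3 is thus expected at 500 nM, within 200 nM to 1500 nM.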

Compound 3, half-maximal inhibitory concentration: 13800 nM
For compound 3 the middle estimate is 28-fold (1.44 log units) below the measured one; measured number above the stated range.
By their numbers in this assay, from the lowest: compound 2; then compound 1; then compound 3.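

In this assay, the step of a 59-fold higher number from compound 1 to compound 3 (1.77 log units; beyond the scatter) is large and beyond the scatter, so inhibition in this pair depends strongly on the chloro on the aromatic carbon para to a large group. The comparison of compound 1 with compound 2 could not show this, as those two differ in more than one place. The change is small in what is counted, with 1 heavy atom leaving and no change in ring count, hydrogen-bond donors, hydrogen-bond acceptors or net charge, yet no evidence at hand accounts for the size of the step.

On these data alone, it remains open whether chloro is specifically required at this place, or whether a fluorine, a bromine, a methyl or a methoxy group would serve as well. The differences between compound 2 and the other two compounds cannot be read as single steps.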